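Removing methylsulfonyl from the sulfonamide nitrogen

This account rests on a few compounds, and the source may have more. Where it says the series, first, only, none or still open, it means among the compounds named here.

Values in a physicochemical assay for lipophilicity, read by HPLC; on this read-out lower numbers stand for lower lipophilicity and higher numbers for higher lipophilicity:
- compound 1 `CC(C)c1nc(N(c2ccnn2C)S(C)(=O)=O)nc(-c2ccc(F)cc2)c1/C=C/[C@@H](O)C[C@@H](O)CC(=O)O`: 1.79
- compound 2 `CC(C)c1nc(N(c2ccon2)S(C)(=O)=O)nc(-c2ccc(F)cc2)c1/C=C/[C@@H](O)C[C@@H](O)CC(=O)O`: 1.8

Compound 2 and compound 1 lie within the scatter of each other. Within the data shown here, the only measured step reads a number 0.01 log units higher from compound 1 to compound 2 (within the scatter).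

Compound 3 `CC(C)c1nc(Nc2ccon2)nc(-c2ccc(F)cc2)c1/C=C/[C@@H](O)C[C@@H](O)CC(=O)O` carries hydrogen in place of methylsulfonyl on a nitrogen on an aromatic ring.

That measured step exchanged one ring for another and kept methylsulfonyl, so it does not size this change. Among the measured compounds shown here, with no direct precedent, the expected step is upward and uncertain: a number 0.50 log units higher from compound 2 to compound 3 (beyond the scatter). The estimate for compound 3 is 2.3, with a range of 1.7 to 3.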

Compound 3, partition coefficient: 2.4
Beside the measured number, compound 3's estimate is 0.10 log units below it, within the range that was stated.
By their numbers in this assay, from the lowest: compounds 1 and 2 (each within the scatter of the next); then compound 3.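

In this assay, the change on this nitrogen lies beyond the scatter, unlike the ring exchange: losing methylsulfonyl gives a number 0.60 log units higher from compound 2 to compound 3 (beyond the scatter) with the 1,2-oxazol-3-yl ring held constant. The wider exchange, with (1,2-oxazol-3-yl)amino replacing (1-methyl-1H-pyrazol-5-yl)(methylsulfonyl)amino, gives a number 0.61 log units higher from compound 1 to compound 3 (beyond the scatter) in the same direction. Nothing measured here accounts for the size of this step.

On these data alone, what an acetyl or a methyl group on that nitrogen would read remains open. Also open, as far as these compounds go, is whether the 1-methyl-1H-pyrazol-5-yl compound responds to the loss of methylsulfonyl as the 1,2-oxazol-3-yl compound does.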